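The source may hold more compounds than are shown below. What is called first, only, known or untested is meant among the compounds shown, and "the series" means these compounds.

The series shares one core: compound 1 `O=C(O)c1csc([C@H]2CC[C@@H]3[C@@H](/C=C/COc4ccccc4)[C@H](O)C[C@@H]3O2)n1`, compound 2 `O=C(O)c1csc([C@H]2CC[C@@H]3[C@@H](/C=C/[C@@H](O)COc4ccccc4)[C@H](O)C[C@@H]3O2)n1`, compound 3 `O=C(O)c1csc([C@H]2CC[C@@H]3[C@@H](CCCCCOc4ccccc4)[C@H](O)C[C@@H]3O2)n1` and the not yet measured compound 4 `O=C(O)c1csc([C@H]2CC[C@@H]3[C@@H](/C=C/CCOc4ccccc4)[C@H](O)C[C@@H]3O2)n1`. In a functional assay on CHO cells for agonist activity at prostaglandin E2 receptor EP4 subtype (Homo sapiens), read by HTRF and cAMP accumulation, with a stated time of 30 min (on this read-out higher numbers stand for an effect only at larger amounts of compound and lower numbers for an effect already at smaller amounts), compound 1 gives only a limit, > 10000 nM, and no number. Compound 2, which carries the 1-hydroxy-2-phenoxyethyl group on the chain, gives 33 nM in this assay. For compound 3, the analogue with the saturated chain, this assay records "not determined" (no result reported). Going by the values given here, the only single-place step that has been measured is an at least 300-fold lower number from compound 1 to compound 2 (2.48 log units; beyond the scatter); it concerns the added hydroxyl, not the length of the chain. Compound 4 differs from compound 1 by phenoxymethyl in place of phenoxy on a saturated chain carbon bound to a double-bonded chain carbon. Among the compounds with values here, no measured step bears directly on this homologation, and compound 1 stands at the limit of > 10000 nM in this assay, at which 1 of the 3 values shown sits, so any change can only be read downward from that limit. Compound 4 is therefore expected to remain weak, with an at least 1.2-fold lower number from compound 1 to compound 4 (0.09 log units; that floor lies within the scatter) as the expected step. The estimate for compound 4 in this assay is 8000 nM, expected to fall between 1000 nM and 30000 nM.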

Compound 4, half-maximal effective concentration: 1900 nM
Estimate against measurement, compound 4: 4.2-fold (0.62 log units) above, within the range that was stated.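

Chain length at this position matters even without a hydroxy group: phenoxymethyl in place of phenoxy gives an at least 5.2-fold lower number from compound 1 to compound 4 (0.72 log units; beyond the scatter), whereas the only step measured earlier concerned the added hydroxyl. The size of this step remains only a floor because compound 1 stands at a limit: the limit of > 10000 nM in this assay, at which 1 of the 4 values shown sits. With the chain length of compound 4 held, the hydroxy group still counts heavily in this assay, with a 58-fold higher number from compound 2 to compound 4 (1.76 log units; beyond the scatter).

Steps involving compound 3 cannot be read, so the part played by the double bond in the chain remains open. Also open, as far as these compounds go, is whether a longer chain than 2-phenoxyethyl would lower the number further, and whether an amine could stand in place of the hydroxy group on the chain.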